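Shortening the side chain beside the sulfonamide in a peptide aldehyde

A few compounds are considered here, and "the series" means these few. Any claim that something is new, unique, unknown or untested is made for them only; others in the source may bear on it.

The account concerns four peptide aldehydes with an arylsulfonamide cap, compared in an assay on isolated protein (Sus scrofa) for inhibition of Calpain-1 catalytic subunit (Homo sapiens); on this read-out lower numbers stand for stronger inhibition and higher numbers for weaker inhibition. Compound 1 `CC(C)C[C@H](C=O)NC(=O)[C@@H](NS(=O)(=O)c1ccc2ccccc2c1)C(C)C` gives 10 nM in this assay. Compound 3 `CC(C)[C@H](NS(=O)(=O)c1ccc(F)cc1)C(=O)N[C@H](C)C=O` gives 630 nM. Compound 2 `CC(C)CC[C@H](NS(=O)(=O)c1ccc(F)cc1)C(=O)N[C@@H](C=O)CC(C)C` gives 260 nM and thus stands second highest of the three numbers: its nearest neighbour is compound 3, whose number is higher by a margin beyond the scatter, and the furthest is compound 1, whose number is lower by a wide margin, also beyond the scatter.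

From compound 2 the account moves to compound 4 `CC(C)C[C@H](NS(=O)(=O)c1ccc(F)cc1)C(=O)N[C@@H](C=O)CC(C)C`, which has not yet been measured in this assay. The change is isopropyl in place of isobutyl on a saturated chain carbon, two bonds along the chain from a carbonyl carbon and a sulfonamide nitrogen. Among the compounds with values here, no pair among the measured compounds differs in exactly this way, so no measured step shows its size. The remaining compounds share the fluorophenylsulfonamide and the aldehyde with compound 2 but differ in several places at once, so they only bracket the region where compound 4 might fall.

Compound 4 is expected to give 110 nM in this assay, within a range from 30 nM to 400 nM. The estimated step of a 2.4-fold lower number from compound 2 to compound 4 (0.37 log units; beyond the scatter) is a modest move towards a lower number, near the edge of the scatter.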

Compound 4, half-maximal inhibitory concentration: 130 nM
Beside the measured number, compound 4's estimate is 1.2-fold (0.07 log units) below it, and the stated range covers the measured number.
By their numbers in this assay, from the lowest: compound 1; then compounds 4 and 2 (each within the scatter of the next); then compound 3.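

Within the data shown here, the swap of isobutyl for isopropyl on a saturated chain carbon, two bonds along the chain from a carbonyl carbon and a sulfonamide nitrogen, now has a measured size in this assay: it gives a 2.0-fold lower number from compound 2 to compound 4 (0.30 log units; within the scatter), the first comparison at this position that differs in one place only. The earlier compounds shown here differed in several places at once and could not separate this chain from the other changes; this pair shows that, with the rest of the structure held constant, the isobutyl and isopropyl chains cannot be told apart on this read-out, so this one-carbon difference leaves no effect that can be distinguished from repeat-measurement variation. Nothing given here explains the result.

The compounds shown leave open how the read-out responds at this carbon to a chain much shorter than these, such as a methyl group, or to a longer chain such as n-hexyl. They also leave open what a phenyl ring, an amine or a carboxylic acid at the end of this chain would do, since every chain compared here is a plain branched one.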